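The source may report more compounds than this note shows. Statements on the series, on what has been measured and on what is new or still open speak of the compounds shown alone.

Of the compounds shown here, three have numbers so far. In an assay on L cells for inhibition of Protein-serine O-palmitoleoyltransferase porcupine (Mus musculus), read by reporter gene assay, with a stated time of 24 h (a higher number here means that more compound is needed for the effect, a lower number that less compound is needed), compound 1 `O=C(CSc1nc2c(c(=O)n1-c1ccccc1)SCC2)Nc1nc(-c2ccccc2)cs1` gives 350 nM. Compound 2 `O=C(CNC(=O)c1nn(-c2ccccc2)c(=O)c2ccccc12)Nc1nc2ccc(C(F)(F)F)cc2s1` gives 110 nM in this assay, and compound 3 `O=C(CNC(=O)c1nn(-c2ccc(F)cc2)c(=O)c2ccccc12)Nc1nc2ccc(C(F)(F)F)cc2s1` gives 90 nM in this assay. Among these three numbers compound 2 stands second highest; its nearest neighbour is compound 3, reached by a 1.2-fold lower number from compound 2 to compound 3 (0.09 log units; within the scatter), and its furthest is compound 1, whose number is higher than that of compound 2 by a margin beyond the scatter.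

Compound 4 `Cc1ccc2nc(NC(=O)CNC(=O)c3nn(-c4ccccc4)c(=O)c4ccccc34)sc2c1` has no number yet. For the measured compounds named here, it differs from compound 2 in one place: methyl in place of trifluoromethyl on an aromatic carbon No measured step touches this position. Going by the values given here, the only measured step, a 1.2-fold lower number from compound 2 to compound 3 (0.09 log units; within the scatter), concerns a fluoro on a different ring and lies within the scatter, so it gives no guidance on size or direction here; the gap between compound 1 and compound 2 is not a single-change comparison, as the core of compound 1 differs. With nothing bearing on the change, the number of compound 4 in this assay is expected to stay close to that of compound 2. The step expected for compound 4 is a 1.6-fold higher number from compound 2 to compound 4 (0.21 log units; within the scatter), within the scatter. Compound 4 is therefore estimated at 180 nM, with a range from 60 nM to 550 nM.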

Compound 4, half-maximal effective concentration: 35 nM
Compound 4: the middle estimate sits 5.1-fold (0.71 log units) above what was measured; the whole stated range lies above it.
By their numbers in this assay, from the lowest: compound 4; then compounds 3 and 2 (each within the scatter of the next); then compound 1.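

For the compounds shown here, at the place on the six-membered carbon ring of the fused system, methyl in place of trifluoromethyl gives in this assay a 3.1-fold lower number from compound 2 to compound 4 (0.50 log units; beyond the scatter) and is the first single change to move the number beyond the scatter, unlike the fluoro change (a 1.2-fold lower number from compound 2 to compound 3 (0.09 log units; within the scatter)). Trifluoromethyl is thus not required at this place for activity in this assay, and the group of one heavy atom gives the lower number than the group of four. No measurement shown accounts for this step.

Open, as far as these compounds go, is whether hydrogen, chlorine, methoxy or a longer chain such as ethyl at this place would extend the step or reverse it. Also open, from the compounds shown here alone, is whether the step would carry over to the fluoro-bearing compound 3.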